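Fluorine on the Core of Compound 1

The source may report more compounds than this note shows. Statements on the series, on what has been measured and on what is new or still open speak of the compounds shown alone.

Compound 1, `COc1cc(Cc2nc3c(N)ncnc3n2CC2CCCO2)cc(OC)c1OC`, was tested in a functional assay on MCF7 cells (Homo sapiens) for antiproliferative activity (on this read-out higher numbers stand for weaker inhibition and lower numbers for stronger inhibition), where compound 1 gives 91200 nM. On the numbers shown it stands second highest of three: compound 3, `COc1cc(Cc2nc3c(N)ncnc3n2CC(C)C)cc(OC)c1OC`, gives 97700 nM, and compound 2, `CC/C=C\Cn1c(Cc2cc(OC)c(OC)c(OC)c2)nc2c(N)ncnc21`, gives 64600 nM. The measured steps are a 1.4-fold lower number from compound 1 to compound 2 (0.15 log units; within the scatter), a 1.1-fold higher number from compound 1 to compound 3 (0.03 log units; within the scatter) and a 1.5-fold higher number from compound 2 to compound 3 (0.18 log units; within the scatter), and each of them changes only the group on the saturated chain carbon bound to an aromatic nitrogen. Compound 4, `COc1cc(Cc2nc3c(N)nc(F)nc3n2CC2CCCO2)cc(OC)c1OC`, differs from compound 1 at a different place: fluoro in place of hydrogen on an aromatic carbon. Among the measured compounds shown here, none of the measured steps touches that aromatic carbon, so they offer no guide to this change, beyond showing that the three measured compounds sit within the scatter of one another. For the measured compounds named here, with no step that bears on it, the expected change is a 1.0-fold lower number from compound 1 to compound 4 (0.00 log units; within the scatter), that is, none beyond the scatter. Compound 4 is therefore estimated at 91000 nM in this assay, with a range from 40000 nM to 200000 nM.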

Compound 4, half-maximal inhibitory concentration: 22900 nM
For compound 4 the middle estimate is 4.0-fold (0.60 log units) above the measured one; measured number outside the range, below it.
By their numbers in this assay, from the lowest: compound 4; then compounds 2, 1 and 3 (each within the scatter of the next).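

In this assay, fluoro in place of hydrogen on the aromatic carbon between two ring nitrogen atoms gives a 4.0-fold lower number from compound 1 to compound 4 (0.60 log units; beyond the scatter) and so lies beyond the scatter, a modest step. Among the compounds shown here, the earlier steps all changed the group on the saturated chain carbon and stayed within the scatter, so this result is the first to show that a change on the core of compound 1 can move the number, and that a single fluorine atom at this aromatic carbon is enough to do so. Nothing shown here gives a reason for this shift. On these data alone, it remains open whether chloro, methyl or an amine on this same carbon would move the number in the same direction or as far. As far as these compounds go, it is also open whether fluoro would give a similar step on compound 2 and compound 3, which carry other groups on the chain.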